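Methylating the hydroxy group of a weak chain-extended flavone

This account rests on a few compounds, and the source may have more. Where it says the series, first, only, none or still open, it means among the compounds named here.

Four compounds share one core, differing in two places: the length of the chain carrying the piperidine ring, and whether the hydroxy group on the aromatic ring is capped by a methyl. Compound 1 `O=c1cc(-c2ccccc2)oc2cc(O)c(OCCCN3CCCCC3)c(O)c12` and compound 2 `COc1cc2oc(-c3ccccc3)cc(=O)c2c(O)c1OCCCN1CCCCC1` carry the shorter chain; compound 3 `O=c1cc(-c2ccccc2)oc2cc(O)c(OCCCCN3CCCCC3)c(O)c12` and compound 4 `COc1cc2oc(-c3ccccc3)cc(=O)c2c(O)c1OCCCCN1CCCCC1` the longer one. In a functional assay on HepG2 cells (Homo sapiens) for antiproliferative activity, read by MTT assay, with a stated time of 48 h (a lower number here means a stronger inhibitor, a higher number a weaker inhibitor), compound 1 gives 70600 nM and compound 2 gives 22300 nM, a change of a 3.2-fold lower number from compound 1 to compound 2 (0.50 log units; beyond the scatter). Compound 3 gives > 100000 nM, which is a limit of this assay rather than a number. Against compound 1 this is an at least 1.4-fold higher number from compound 1 to compound 3 (0.15 log units; that floor lies within the scatter); it is one of the values sitting at the limit of > 100000 nM in this assay, at which 1 of the 3 values shown sits.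

Compound 4 differs from compound 3 by methyl in place of hydrogen on an oxygen on an aromatic ring. Going by the values given here, the only measured step bearing on this change is the one from compound 1 to compound 2, which lowered the number beyond the scatter. A step of similar size and direction is therefore expected for compound 4, though compound 3 starts from a limit, so the starting point itself is uncertain. Compound 4 is expected to give 45000 nM, between 15000 nM and 150000 nM. That estimate means an expected step of an at least 2.2-fold lower number from compound 3 to compound 4 (0.34 log units; beyond the scatter).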

Compound 4, half-maximal inhibitory concentration: 21000 nM
Compound 4: middle estimate off by 2.1-fold (0.33 log units), on the high side, within the range that was stated.
By their numbers in this assay, from the lowest: compounds 4 and 2 (each within the scatter of the next); then compound 1. At a limit, above all of these: compound 3.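

In this assay, the change from hydroxy to methoxy on the longer chain gives an at least 4.7-fold lower number from compound 3 to compound 4 (0.67 log units; beyond the scatter), so the number falls with this change on both chain lengths, not only on the shorter one: the same change on two cores in this assay, a 3.2-fold lower number (0.50 log units; beyond the scatter) from compound 1 to compound 2 and an at least 4.7-fold lower number (0.67 log units; beyond the scatter) from compound 3 to compound 4; the limit leaves it open whether they differ Compound 3 gives > 100000 nM, which is a limit of the assay. Among the methoxy compounds, (piperidin-1-yl)methyl in place of piperidin-1-yl gives a 1.1-fold lower number from compound 2 to compound 4 (0.03 log units; within the scatter), so once the methoxy group is present the two chain lengths cannot be told apart in this assay: the same change on two cores in this assay, an at least 1.4-fold higher number (0.15 log units; that floor lies within the scatter) from compound 1 to compound 3 and a 1.1-fold lower number (0.03 log units; within the scatter) from compound 2 to compound 4; the limit leaves it open whether they differ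

As far as these compounds go, how far compound 3 really lies from compound 1 remains open, and with it whether the methoxy step truly differs in size between the two chains. Going by these compounds alone, also open is whether an ethyl group on the same oxygen, or a chain longer than the one in compound 4, would carry the number lower or leave it where compounds 2 and 4 already sit.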